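The source may hold more compounds than are shown below. What is called first, only, known or untested is meant among the compounds shown, and "the series" means these compounds.

Measured values in a functional assay on CHO cells for agonist activity at Free fatty acid receptor 1 (Homo sapiens), read by FLIPR, tested at 100 nM; on this read-out lower numbers stand for a weaker effect and higher numbers for a stronger effect at the one concentration tested:

- compound 1 `Cc1ccc(NC(=O)C(=O)Nc2ccc(OCC(=O)O)c(F)c2)cc1`: 11.4%
- compound 2 `Cc1ccc(OCC(=O)Nc2ccc(OCC(=O)O)c(F)c2)cc1`: 31.2%
- compound 3 `CC(C)c1ccc(OCC(=O)Nc2ccc(OCC(=O)O)c(F)c2)cc1`: 11.8%

In this assay compound 3 sits close to compound 1, the two values lying within the scatter of each other, so no order between them can be read. Against compound 2 the gap is real: a number 19.4 percentage points lower from compound 2 to compound 3 (beyond the scatter). Going by the values given here, that step, isopropyl in place of methyl on an aromatic carbon, is the only single-point change measured.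

The next compound, compound 4 `O=C(O)COc1ccc(NC(=O)COc2ccc(OC(F)(F)F)cc2)cc1F`, has not been measured in this assay. It differs from compound 3 as follows: trifluoromethoxy in place of isopropyl on an aromatic carbon. Among the compounds with values here, no measured step exchanges a trifluoromethoxy group for anything, so the one measured step bears on this change only indirectly: it shows that altering the group at this position does move the read-out in this assay by a modest amount, but it does not indicate in which direction a trifluoromethoxy group would move it. Compound 4 is therefore expected to land near compound 3, with a step of a number 4.2 percentage points higher from compound 3 to compound 4 (within the scatter) expected, one that may not exceed the scatter. In this assay compound 4 is estimated at 16%, within a range from 5% to 35%.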

Compound 4, a percentage reported as activity, at one concentration (the size of the read-out at that concentration, not a potency): 6.45%
Estimate against measurement, compound 4: 9.6 percentage points above; the measured number falls inside the stated range.
By their numbers in this assay, from the lowest: compounds 4, 1 and 3 (each within the scatter of the next); then compound 2.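

In this assay, the exchange on the aromatic carbon para to a large group gives a number 5.4 percentage points lower from compound 3 to compound 4 (within the scatter), so isopropyl and trifluoromethoxy cannot be told apart here, even though they differ in heavy atoms and in hydrogen-bond acceptors. Compared with methyl, the change gives a number 24.8 percentage points lower from compound 2 to compound 4 (beyond the scatter), so a second replacement of methyl now also reads lower, and among compounds 2, 3 and 4, compound 2 with its methyl group stands alone at the top of the read-out. No available evidence accounts for either step.

Still open, from the compounds shown here alone, is whether an ethyl group, a chlorine atom or a plain hydrogen at this position would read close to compound 2 or close to compound 3 and compound 4, which would show how narrow the preference for methyl is. Also open, going by these compounds, is whether this order holds at other concentrations, since a reading at a single concentration is not a potency and says nothing about how these compounds would rank across a full dose range.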